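Adding Bromo to the Core of Compound 3

This account rests on a few compounds, and the source may have more. Where it says the series, first, only, none or still open, it means among the compounds named here.

The study measures each compound in a functional assay on the whole organism (strain albino) for inhibition, with Rattus norvegicus as the target, read by paw edema, with a stated time of 120 min, at a dose of 100 mg/kg by the oral route; a lower number here means less inhibition, a higher number more inhibition at the dose given (going by the name of the read-out). Compound 1 `Clc1ccccc1NCc1nc2ccc(Br)cc2[nH]1` gives 23.5% in this assay, and compound 2 `Cc1ccc(NCc2nc3ccc(Br)cc3[nH]2)cc1` gives 23.5%. Compound 3 `c1ccc(NCc2nc3ccccc3[nH]2)cc1` gives 41.1%, the highest of the three numbers, lying beyond the scatter above both compound 1 and compound 2. Compound 1 and compound 2 both carry bromo on the shared core together with a substituent on the other ring, so their lower numbers cannot be traced to one change alone.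

Compound 4 `Brc1ccc2nc(CNc3ccccc3)[nH]c2c1` has not been measured in this assay. Compared with compound 3 it differs as follows: bromo in place of hydrogen on an aromatic carbon. Both compounds that carry bromo on the core, compound 1 with 23.5% and compound 2 with 23.5%, stand below compound 3, so a downward step is expected, though its size is uncertain. Compound 4 is expected to give about 30% in this assay, within a range from 16% to 44%, which corresponds to an expected step of a number 11.1 percentage points lower from compound 3 to compound 4 (beyond the scatter).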

Compound 4, a percentage reported as inhibition, in the whole organism at one dose (the size of the read-out at that dose, not a potency): 29.4%
The estimate for compound 4 lay 0.6 percentage points above the measured number, within the range that was stated.
By their numbers in this assay, from the lowest: compounds 1, 2 and 4 (each within the scatter of the next); then compound 3.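

Taken alone, bromo in place of hydrogen on an aromatic carbon of the shared core gives a number 11.7 percentage points lower from compound 3 to compound 4 (beyond the scatter) in this assay and so isolates a single change that the earlier compounds could not separate. Hydrogen in place of methyl on an aromatic carbon gives a number 5.9 percentage points higher from compound 2 to compound 4 (within the scatter) and hydrogen in place of chloro on an aromatic carbon gives a number 5.9 percentage points higher from compound 1 to compound 4 (within the scatter) so with bromo on the core, neither group on the other ring stands apart from hydrogen.

The compounds shown leave open whether fluoro, methoxy or an amine at this position of the core would give a number like that of bromo. They also leave open what methyl or chloro on the other ring would do without bromo on the core. Nothing shown here accounts for the step from hydrogen to bromo.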